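Isoxazolidine chromone series: ester to ethoxy swap

The source may hold more compounds than are shown below. What is called first, only, known or untested is meant among the compounds shown, and "the series" means these compounds.

Measured compounds:
- compound 1, `COC(=O)[C@@]1(C)C[C@@H](c2coc3ccc(Br)cc3c2=O)N(c2ccccc2)O1`: in a functional assay on PC-3 cells (Homo sapiens) for inhibition, read by sulforhodamine B assay, with a stated time of 48 h (a lower number here means a stronger inhibitor, a higher number a weaker inhibitor), compound 1 reaches only the limit > 60000 nM
- compound 2, `COC(=O)[C@H]1C[C@@H](c2coc3ccccc3c2=O)N(c2ccccc2)O1`: in this assay compound 2 likewise reaches only the limit > 60000 nM

For the measured compounds named here, both values known so far are limits, not numbers, and both sit at the limit of > 60000 nM in this assay, at which 2 of the 2 values shown sit. Compound 2 therefore stands nowhere on a scale of numbers; it is known only to be weaker than the assay can resolve. Going by the values given here, compound 1 gives no more than that either, so no step between measured compounds exists.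

Compound 3, `CCO[C@H]1C[C@@H](c2coc3ccccc3c2=O)N(c2ccccc2)O1`, is drawn from compound 2 by ethoxy in place of methoxycarbonyl on a saturated ring carbon. With both measured compounds at the same limit, no direction can be read from the data; compound 3 is expected to remain at or near that limit, with an expected step that the limit leaves unreadable from compound 2 to compound 3 of no meaning beyond the scatter. The estimate for compound 3 in this assay is 80000 nM, with a range from 30000 nM to 200000 nM.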

Compound 3, half-maximal inhibitory concentration: > 60000 nM
Compound 3 was reported as a limit; the forecaster's own chance of this, stated with the estimate: 80%; the middle value is on the limit's open side.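

No step can be read from compound 2 to compound 3 in this assay, since both are reported only as limits: the limit of > 60000 nM in this assay, at which 3 of the 3 values shown sit.

The compounds shown leave open how ethoxy and methoxycarbonyl compare, and whether any group on the shared core gives a measurable inhibition in this assay.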